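Compound 4: isopropyl in place of methyl

The compounds below may be only part of what the source reports. "The series", "measured", "known", "first", "only" and "open" are said of these compounds alone.

- Compound 1 `C/C=C1/[C@H](O[C@@H]2O[C@H](CO)[C@@H](O)[C@H](O)[C@H]2O)OC=C(C(=O)OC)[C@H]1CC(=O)OCCCCCCCCCCCCCCC`: 1600 nM
- Compound 2 `C/C=C1/[C@H](O[C@@H]2O[C@H](CO)[C@@H](O)[C@H](O)[C@H]2O)OC=C(C(=O)OC)[C@H]1CC(=O)OCc1ccc2c(c1)OCCO2`: > 15000 nM, a limit
- Compound 3 `C/C=C1/[C@H](O[C@@H]2O[C@H](CO)[C@@H](O)[C@H](O)[C@H]2O)OC=C(C(=O)OC)[C@H]1CC(=O)OCCC`: > 15000 nM, a limit

These results come from a functional assay on SK-BR-3 cells (Homo sapiens) for antiproliferative activity, read by MTT assay, with a stated time of 72 h; a lower number here means a stronger inhibitor, a higher number a weaker inhibitor. Compound 3 has only a limit, not a number, and sits at the limit of > 15000 nM in this assay, at which 2 of the 3 values shown sit.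

Compound 4 `C/C=C1/[C@H](O[C@@H]2O[C@H](CO)[C@@H](O)[C@H](O)[C@H]2O)OC=C(C(=O)OC)[C@H]1CC(=O)OCCC(C)C` differs from it by isopropyl in place of methyl on a saturated chain carbon, two bonds along the chain from an oxygen next to a carbonyl group, with isopropyl in place of methyl on a saturated chain carbon. The clearest guide is an at least 9.3-fold higher number from compound 1 to compound 3 (0.97 log units; beyond the scatter), where hydrogen replaces dodecyl. The other measured step, a step that the two limits leave unreadable from compound 2 to compound 3, gives no size. Compound 4 adds far less chain than dodecyl, so only a small move towards stronger inhibition is expected, and it may stay at the limit. The expected change is an at least 1.2-fold lower number from compound 3 to compound 4 (0.09 log units; that floor lies within the scatter). For compound 4 the estimate is 12000 nM, with an expected range of 5000 nM to 30000 nM.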

Compound 4, half-maximal inhibitory concentration: 9020 nM
Compound 4: the middle estimate sits 1.3-fold (0.12 log units) above what was measured; measured number inside the range.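

Isopropyl in place of methyl, two bonds along the chain from an oxygen next to a carbonyl group, shows that a chain far shorter than that of compound 1 can still give a readable number. Two steps follow: an at least 1.6-fold lower number from compound 3 to compound 4 (0.22 log units; that floor lies within the scatter), and an at least 1.6-fold lower number from compound 2 to compound 4 (0.22 log units; that floor lies within the scatter). These are only floors, and the true size stays unknown, because compound 2 and compound 3 each carry a limit rather than a number: the limit of > 15000 nM in this assay, at which 2 of the 4 values shown sit.

The compounds shown leave open how a chain of intermediate length, such as octyl, would read. Also open, from the compounds shown here alone, is what an amine or a carboxylic acid in place of isopropyl would give.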